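The source may report more compounds than this note shows. Statements on the series, on what has been measured and on what is new or still open speak of the compounds shown alone.

Measured in a physicochemical assay for permeability, using PAMPA, at pH 7.4; on this read-out higher numbers stand for higher permeability and lower numbers for lower permeability:
Compound 1 `O=C(NS(=O)(=O)c1ccccc1)c1ccc(Nc2nc(NC3(c4ccc(Cl)cc4)CC3)nc(OCC(F)(F)F)n2)cc1` gives 182 nm/s.
Compound 2 `CNC(=O)NCCS(=O)(=O)NC(=O)c1ccc(Nc2nc(NC3(c4ccc(Cl)cc4)CC3)nc(OCC(F)(F)F)n2)cc1` gives 40 nm/s.
Compound 3 `CS(=O)(=O)NC(=O)c1ccc(Nc2nc(NC3(c4ccc(Cl)cc4)CC3)nc(OCC(F)(F)F)n2)cc1` gives 11 nm/s.

Compound 1 stands highest of the three in this assay; compound 2 lies nearest below it and compound 3 furthest. Compound 4 `NCCS(=O)(=O)NC(=O)c1ccc(Nc2nc(NC3(c4ccc(Cl)cc4)CC3)nc(OCC(F)(F)F)n2)cc1` differs from compound 1 by 2-aminoethyl in place of phenyl on a sulfonyl sulfur. Among the compounds with values here, two measured steps bear on this change: a 4.6-fold lower number from compound 1 to compound 2 (0.66 log units; beyond the scatter) and a 17-fold lower number from compound 1 to compound 3 (1.22 log units; beyond the scatter). Both replace the phenyl on the sulfonyl sulfur with a smaller group, and both lower the number in this assay. The group entering in compound 4 is likewise smaller than phenyl and carries a donor and an acceptor, so compound 4 is expected to show a large drop in this assay, a 23-fold lower number from compound 1 to compound 4 (1.36 log units; beyond the scatter). Compound 4 is estimated at 8 nm/s, with a range of 2 nm/s to 30 nm/s.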

Compound 4, apparent permeability: 153 nm/s
Compound 4: the middle estimate sits 19-fold (1.28 log units) below what was measured; the whole stated range lies below it.
By their numbers in this assay, from the lowest: compound 3; then compound 2; then compounds 4 and 1 (each within the scatter of the next).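

In this assay, a group smaller than phenyl on the sulfonyl sulfur does not have to bring a drop: 2-aminoethyl in its place gives a 1.2-fold lower number from compound 1 to compound 4 (0.08 log units; within the scatter). The substituent on the chain matters as well, with aminomethyl in place of hydrogen on the saturated chain carbon giving a 14-fold higher number from compound 3 to compound 4 (1.14 log units; beyond the scatter), and hydrogen in place of methylcarbamoyl on the amine nitrogen giving a 3.8-fold higher number from compound 2 to compound 4 (0.58 log units; beyond the scatter). No measurement given here accounts for these steps. Going by these compounds, it remains open whether the amine or the length of the chain carries these steps. A 3-aminopropyl, 2-hydroxyethyl or 2-(dimethylamino)ethyl group on the sulfonyl sulfur could separate the two.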